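Diethylamino in place of dimethylamino on the weaker compound

The compounds below may be only part of what the source reports. "The series", "measured", "known", "first", "only" and "open" are said of these compounds alone.

In a functional assay on NCI-H460 cells (Homo sapiens) for cytotoxicity, read by MTT assay, with a stated time of 72 h (a higher number here means a weaker inhibitor, a lower number a stronger inhibitor), compound 1 (`CCN(CC)Cc1ccc2nc(NC(=O)N/N=C/c3cn(Cc4ccc(C)cc4)c4ccccc34)sc2c1`) reads 320 nM and compound 2 (`CN(C)Cc1ccc2nc(NC(=O)N/N=C/c3c[nH]c4ccccc34)sc2c1`) reads 2550 nM as the higher number of the two, a gap beyond the scatter. Compound 3 (`CCN(CC)Cc1ccc2nc(NC(=O)N/N=C/c3c[nH]c4ccccc34)sc2c1`) has diethylamino in place of dimethylamino on a saturated chain carbon bound to an aromatic carbon. Among the measured compounds shown here, compound 1 also bears diethylamino but differs from compound 2 elsewhere too, so no measured step isolates this change. In this assay the estimated step of a 1.4-fold lower number from compound 2 to compound 3 (0.15 log units; within the scatter) is expected to stay within the scatter, if anything toward a lower number. Compound 3 is estimated at 1800 nM (expected range 700 nM to 4000 nM).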

Compound 3, half-maximal inhibitory concentration: 3140 nM
Compound 3: middle estimate off by 1.7-fold (0.24 log units), on the low side; low and high end bracket the measured number.
By their numbers in this assay, from the lowest: compound 1; then compounds 2 and 3 (each within the scatter of the next).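

In this assay the change from dimethylamino to diethylamino on a saturated chain carbon bound to an aromatic carbon gives a 1.2-fold higher number from compound 2 to compound 3 (0.09 log units; within the scatter) and so does not separate the two amines. Compound 3 also isolates the aromatic nitrogen: hydrogen in place of 4-methylbenzyl gives a 9.8-fold higher number from compound 1 to compound 3 (0.99 log units; beyond the scatter) and accounts for the gap seen earlier. No measured evidence bears on the reason for either step.

As far as these compounds go, whether 4-methylbenzyl has the same effect alongside dimethylamino remains open. So do the readings for pyrrolidine or morpholine at the amine and for unsubstituted benzyl on the aromatic nitrogen.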